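The source may report more compounds than this note shows. Statements on the series, on what has been measured and on what is new or still open speak of the compounds shown alone.

Compound 1 `CCCCCCCCN(C)C(=O)Cn1cc(Cc2cnc(=O)n(C)c2)c(=O)nc1SCc1ccc(F)cc1` gives 55% in a functional assay on a cell-free system (plasma) for inhibition of platelet-activating factor acetylhydrolase (Homo sapiens), tested at 100 nM; on this read-out lower numbers stand for less inhibition and higher numbers for more inhibition at the one concentration tested (going by the name of the read-out).
Compound 2 `CCCCCCCCCCCCN(C)C(=O)Cn1cc(Cc2cnc(=O)n(C)c2)c(=O)nc1SCc1ccc(F)cc1` gives 75% in this assay.
Compound 3 `CCCCCCCCCCCCN(C)C(=O)Cn1cc(Cc2cnc(=O)n(CCO)c2)c(=O)nc1SCc1ccc(F)cc1` gives 77% in this assay.

Compound 1 has the lowest number of the three: compound 2 sits a number 20 percentage points higher from compound 1 to compound 2 (beyond the scatter), and compound 3 sits higher still. Compound 4 `CCCCCCCCN(C)C(=O)Cn1cc(Cc2cnc(=O)n(CC(=O)NC)c2)c(=O)nc1SCc1ccc(F)cc1` is derived from compound 1 by one change: methylcarbamoyl in place of hydrogen on a saturated chain carbon bound to an aromatic nitrogen. For the measured compounds named here, of the measured steps, the one from compound 2 to compound 3 is the closest guide, since it also adds a group on a saturated chain carbon bound to an aromatic nitrogen; that step was a number 2 percentage points higher from compound 2 to compound 3 (within the scatter), a change that stays within the usual scatter. The step from compound 1 to compound 2 alters a different part of the molecule, the eight-carbon chain on the amide-type nitrogen, and compound 4 keeps that chain unchanged from compound 1, so it does not bear on this step. The expectation is therefore that compound 4 differs little from compound 1, with a number 1 percentage points higher from compound 1 to compound 4 (within the scatter) as the estimated shift. Compound 4 is estimated at 56%, within a range from 42% to 70%.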

Compound 4, a percentage reported as inhibition, at one concentration (the size of the read-out at that concentration, not a potency): 63%
Compound 4: middle estimate off by 7 percentage points, on the low side; the measured number falls inside the stated range.
By their numbers in this assay, from the lowest: compounds 1 and 4 (each within the scatter of the next); then compounds 2 and 3 (each within the scatter of the next).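

Replacing the methyl on the aromatic nitrogen with (methylcarbamoyl)methyl gives a number 8 percentage points higher from compound 1 to compound 4 (within the scatter) in this assay and so shows no clear gain or loss. For the compounds shown here, until now, the only change at this place was the smaller hydroxymethyl addition, which gave a number 2 percentage points higher from compound 2 to compound 3 (within the scatter) on the compound with the longer chain on the amide-type nitrogen; this result extends that picture to a group of 4 heavy atoms carrying a hydrogen-bond donor and acceptor, and to the shorter-chain compound. Nothing measured here explains why the inhibition holds up with either group.

On these data alone, whether methylcarbamoyl would behave the same way on the longer-chain compound remains open. So does the outcome at this place for a carboxylic acid, an amine or a longer chain ending in a hydroxyl.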